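The source may report more compounds than this note shows. Statements on the series, on what has been measured and on what is new or still open speak of the compounds shown alone.

Measured so far in a functional assay on HT-29 cells (Homo sapiens) for antiproliferative activity, read by sulforhodamine B assay, with a stated time of 48 h; a higher number here means a weaker inhibitor of growth, a lower number a stronger inhibitor of growth:

Compound 1 `CCCCc1ccc(-c2cc(N3CCC(CCNS(N)(=O)=O)CC3)ncn2)cc1`: 13300 nM
Compound 2 `NS(=O)(=O)NCCC1CCN(c2cc(-c3ccc(Cl)cc3)ncn2)CC1`: 30500 nM

Among the measured compounds shown here, compound 2 stands at the higher of the two numbers in this assay; its only neighbour is compound 1, and the step between them is a 2.3-fold higher number from compound 1 to compound 2 (0.36 log units; beyond the scatter), a change of the group on the aromatic ring. Compound 3 `NS(=O)(=O)NCCC1CCN(c2cc(-c3ccc(C(F)(F)F)cc3)ncn2)CC1` has not yet been measured. It differs from compound 2 in one place: trifluoromethyl in place of chloro on an aromatic carbon. For the measured compounds named here, the one measured step bears on this same position and was modest, so the new group is expected to move the number by at most a comparable amount. Since trifluoromethyl is neither the butyl of compound 1 nor the chloro of compound 2, compound 3 is expected to give a number somewhat lower than that of compound 2, with an estimated step of a 1.4-fold lower number from compound 2 to compound 3 (0.14 log units; within the scatter). Compound 3 is therefore estimated at 22000 nM in this assay, in a range from 9000 nM to 60000 nM.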

Compound 3, concentration for 50% growth inhibition: 22600 nM
Compound 3: middle estimate off by 1.0-fold (0.01 log units), on the low side; low and high end bracket the measured number.
By their numbers in this assay, from the lowest: compounds 1, 3 and 2 (each within the scatter of the next, the first and the last beyond it).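

In this assay, trifluoromethyl in place of chloro, which swaps one heavy atom for four on the aromatic carbon para to a large group, gives a 1.3-fold lower number from compound 2 to compound 3 (0.13 log units; within the scatter), and trifluoromethyl in place of butyl gives a 1.7-fold higher number from compound 1 to compound 3 (0.23 log units; within the scatter). Compound 3 therefore cannot be told apart from either neighbour, even though the butyl and chloro compounds differ by a 2.3-fold higher number from compound 1 to compound 2 (0.36 log units; beyond the scatter), so the third group adds a point that fills the gap between them rather than a clear new level at this position. Nothing on hand gives a reason for the size of these steps. The compounds shown leave open whether an amine, a carboxylic acid or a chain longer than butyl on this carbon would move the number further. They also leave open whether a change elsewhere on the shared core would matter more than any change here.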